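Working notes: acetamido in place of fluoro

The source may hold more compounds than are shown below. What is called first, only, known or untested is meant among the compounds shown, and "the series" means these compounds.

In a functional assay on PC-3 cells (Homo sapiens) for inhibition, read by sulforhodamine B assay (on this read-out higher numbers stand for weaker inhibition of growth and lower numbers for stronger inhibition of growth), compound 3 `O=C(CCC1=CCCN(Cc2ccc(F)cc2)C1=O)NO` has the entry "not determined" (no result reported), so it stands without a number of its own. Its neighbours offer little more. Compound 1 `COc1ccccc1CN1CCC=C(CCC(=O)NO)C1=O` gives > 10000 nM, which is a limit of the assay. Compound 2 `COc1cccc(CN2CCC=C(CCC(=O)NO)C2=O)c1` gives > 10000 nM, also a limit. Going by the values given here, the series so far therefore shows (the limit of > 10000 nM in this assay, at which 2 of the 3 values shown sit).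

Compound 4 is `CC(=O)Nc1ccc(CN2CCC=C(CCC(=O)NO)C2=O)cc1`. The change is acetamido in place of fluoro on an aromatic carbon, para to a large group: acetamido in place of fluoro on an aromatic carbon.

Among the compounds with values here, no measured step exists for this change. Resting on compound 2 at > 10000 nM, a limit, no step beyond the scatter is expected in this assay, in either direction. Compound 4 is estimated at 10000 nM, with an expected range of 4000 nM to 30000 nM.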

Compound 4, concentration for 50% growth inhibition: > 10000 nM
Compound 4 was reported as a limit; the forecaster's own chance of this, stated with the estimate: 70%; the middle value lies on the limit itself.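

Compound 4 gives > 10000 nM in this assay, a limit and not a number. Going by these compounds alone, compound 3 carries no number, so no step to compound 4 can be read. The compounds shown leave open how strongly any of them inhibits growth: the limit of > 10000 nM in this assay, at which 3 of the 4 values shown sit.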